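From ethoxy to chloro on a shared core

The compounds below may be only part of what the source reports. "The series", "measured", "known", "first", "only" and "open" are said of these compounds alone.

Of the compounds shown here, two built on one shared core have been measured so far. Compound 1 `O=C1C2ON=C(c3cn(-c4ccccc4)nc3-c3ccc(Br)cc3)C2C(=O)N1c1ccccc1` carries a bromo group on an outer aromatic ring, and compound 2 `CCOc1ccc(-c2nn(-c3ccccc3)cc2C2=NOC3C(=O)N(c4ccccc4)C(=O)C23)cc1` carries an ethoxy group at that same place. In a functional assay on the whole organism (Abdomen, strain Swiss albino) with Mus musculus as the target, with stated times of 10 min and 5 min, at a dose of 30 mg/kg by the oral route (a higher number here means a stronger effect of the compound at the dose given, a lower number a weaker effect), compound 1 gives 49%, and compound 2 gives 49.5%. On these numbers compound 2 stands alongside compound 1: the step of a number 0.5 percentage points higher from compound 1 to compound 2 (within the scatter) is within the scatter, so the two cannot be told apart.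

Compound 3 `O=C1C2ON=C(c3cn(-c4ccccc4)nc3-c3ccc(Cl)cc3)C2C(=O)N1c1ccccc1` has not yet been measured. It differs from compound 2 in one place: chloro in place of ethoxy on an aromatic carbon. Among the compounds with values here, the only measured step that bears on this change is a number 0.5 percentage points higher from compound 1 to compound 2 (within the scatter), where bromo gave way to ethoxy and the reading hardly moved; a halogen and the ethoxy group thus gave the same result within the scatter. Chloro, like bromo, is a halogen, so no step beyond the scatter is expected in this assay. For compound 3 the expected step is a number 0.5 percentage points lower from compound 2 to compound 3 (within the scatter), giving an estimate of 49%, with a range from 36% to 62%.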

Compound 3, a percentage reported as activity, at one dose (the size of the read-out at that dose, not a potency): 43.2%
Compound 3: middle estimate off by 5.8 percentage points, on the high side; low and high end bracket the measured number.
By their numbers in this assay, from the lowest: compounds 3, 1 and 2 (each within the scatter of the next).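

In this assay, within the data shown here, chloro joins bromo and ethoxy at this position, on the outer six-membered aromatic ring and para to a large group, and the reading still cannot be separated from those of the earlier compounds: the change from ethoxy gives a number 6.3 percentage points lower from compound 2 to compound 3 (within the scatter) and the change from bromo gives a number 5.8 percentage points lower from compound 1 to compound 3 (within the scatter) as well. Two halogens can now be compared directly, and at this dose the exchange of one for the other leaves no readable difference. The change from 4-ethoxyphenyl to 4-chlorophenyl removes a hydrogen-bond acceptor and several heavy atoms, yet it also stays within the scatter, so neither feature has been shown to matter at this position in this test.

The compounds shown leave open whether any group placed here can move the reading beyond the scatter, for example an amine, a carboxylic acid or a longer chain in place of ethoxy. Nothing measured here offers an explanation for how closely these three readings lie.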